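A few compounds are considered here, and "the series" means these few. Any claim that something is new, unique, unknown or untested is made for them only; others in the source may bear on it.

Measured so far in a functional assay on the whole organism (strain Swiss albino) with Mus musculus as the target, with a stated time of 0.5 h; a lower number here means that less compound is needed, a higher number that more compound is needed for the effect:
- compound 1, `O=C(/N=C/c1ccccc1)Nc1ccc2c(c1)C(=O)C(=O)N2CN1CCCCC1` — in this assay compound 1 gives 300 mg/kg
- compound 2, `O=C(/N=C/c1ccc(F)cc1)Nc1ccc2c(c1)C(=O)C(=O)N2CN1CCCCC1` — in this assay compound 2 gives 100 mg/kg
- compound 3, `O=C(/N=C/c1ccc([N+](=O)[O-])cc1)Nc1ccc2c(c1)C(=O)C(=O)N2CN1CCCCC1` — in this assay compound 3 gives 300 mg/kg

Compound 3 sits level with compound 1 at the highest number of the three in this assay; no change at the digits printed from compound 1 to compound 3 (within the scatter). Compound 2 is the one that stands apart: a 3.0-fold lower number from compound 1 to compound 2 (0.48 log units; beyond the scatter), and against compound 3 the gap reads as a 3.0-fold higher number from compound 2 to compound 3 (0.48 log units; beyond the scatter). All three share the same core, so the whole spread so far comes from the single substituent on the phenyl ring of the imine arm.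

Compound 4, `Cc1ccc(/C=N/C(=O)Nc2ccc3c(c2)C(=O)C(=O)N3CN2CCCCC2)cc1`, is the next member and differs from compound 3 as follows: methyl in place of nitro on an aromatic carbon. Among the compounds with values here, no measured step exchanges nitro for methyl, so the bearing of the measured steps is indirect. Nitro in place of hydrogen left the number unchanged (no change at the digits printed from compound 1 to compound 3 (within the scatter)), while fluoro in place of hydrogen lowered it modestly (a 3.0-fold lower number from compound 1 to compound 2 (0.48 log units; beyond the scatter)). Within the data shown here, a methyl substituent therefore has no direct precedent; the nearest guidance is that two of the three substituents gave the same number and one gave a modestly lower one. In this assay compound 4 is expected to move as a 1.5-fold lower number from compound 3 to compound 4 (0.18 log units; within the scatter), that is, no change beyond the scatter, with a modest lowering not excluded. The estimate for compound 4 in this assay is 200 mg/kg, between 100 mg/kg and 400 mg/kg.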

Compound 4, minimum effective dose: 300 mg/kg
Beside the measured number, compound 4's estimate is 1.5-fold (0.18 log units) below it; low and high end bracket the measured number.
By their numbers in this assay, from the lowest: compound 2; then compounds 1, 3 and 4 (each within the scatter of the next).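

In this assay the exchange of nitro for methyl at this position reads as a null step (no change at the digits printed from compound 3 to compound 4 (within the scatter)), and methyl in place of hydrogen reads the same way (no change at the digits printed from compound 1 to compound 4 (within the scatter)), so compound 4 adds a third group, and the first carbon substituent, to the level already shared by compound 1 and compound 3. Fluoro is now the lone exception among the four, since methyl in place of fluoro gives a clear step (a 3.0-fold higher number from compound 2 to compound 4 (0.48 log units; beyond the scatter)), and compound 2 is the only member that goes against the level reading; in this small set the lower number goes with fluoro and not with the presence of a substituent as such. Nothing in the information at hand accounts for this single departure.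

From the compounds shown here alone, whether the lower number is specific to fluoro stays open, as chloro, bromo, methoxy, an amine, a carboxylic acid or a longer chain such as ethyl at this position could either join compound 2 or fall in with the others. Within the data shown here, also open is whether the single step from hydrogen to fluoro would hold on a different ring position or with changes elsewhere on the shared core.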